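The source may report more compounds than this note shows. Statements on the series, on what has been measured and on what is new or still open speak of the compounds shown alone.

Working notes on the series. In an assay on isolated protein for inhibition of Nicotinamide phosphoribosyltransferase (Homo sapiens), read by mass spectrometry, with stated times of 15 min and 30 min (a lower number here means a stronger inhibitor, a higher number a weaker inhibitor), compound 2 `CCC(=O)N1CCC(S(=O)(=O)c2ccc(CNC(=O)N3Cc4ccncc4C3)cc2)CC1` gives 27 nM. Among the measured compounds shown here, compound 1 `O=C(NCc1ccc(S(=O)(=O)C2CCCOC2)cc1)N1Cc2ccncc2C1` gives 44 nM in this assay, and the only measured step is a 1.6-fold lower number from compound 1 to compound 2 (0.21 log units; within the scatter), so compound 2 holds the lower of the two numbers without standing apart from compound 1. Compound 3 `O=C(NCc1ccc(S(=O)(=O)C2CCN(C3COC3)CC2)cc1)N1Cc2ccncc2C1` awaits measurement in this assay. It differs from compound 2 by oxetan-3-yl in place of propanoyl on an amine nitrogen in a ring. For the measured compounds named here, no measured step touches the amine nitrogen in the ring; the single step available concerns the group on the sulfonyl sulfur and stayed within the scatter, so it gives no direct precedent. The working expectation is therefore no step beyond the scatter, and the step of a 1.1-fold higher number from compound 2 to compound 3 (0.05 log units; within the scatter) is what that estimate means. In this assay compound 3 is expected to give about 30 nM, within a range of 12 nM to 80 nM.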

Compound 3, half-maximal inhibitory concentration: 31 nM
Estimate against measurement, compound 3: 1.0-fold (0.01 log units) below; the measured number falls inside the stated range.
By their numbers in this assay, from the lowest: compounds 2, 3 and 1 (each within the scatter of the next).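

Oxetan-3-yl in place of propanoyl on the amine nitrogen in the ring gives, in this assay, a 1.1-fold higher number from compound 2 to compound 3 (0.06 log units; within the scatter), so at this position a four-membered ring with a ring oxygen and an acyl group with a carbonyl, each of the same heavy-atom count, cannot be told apart. On the sulfonyl sulfur, 1-(oxetan-3-yl)piperidin-4-yl in place of oxan-3-yl gives a 1.4-fold lower number from compound 1 to compound 3 (0.15 log units; within the scatter), which adds a second piperidine-bearing compound that lies within the scatter of the oxan-3-yl compound. Nothing at hand explains why these numbers lie so close.

As far as these compounds go, both groups compared on this nitrogen have the same heavy-atom count, so the effect of a larger group there, such as benzyl or a longer acyl chain, remains open. Also open, from the compounds shown here alone, is how a carboxylic acid on that chain, or a free ring amine with only hydrogen on the nitrogen, would read.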